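From benzyl to 4-fluorobenzyl on an antiproliferative scaffold

A few compounds are considered here, and "the series" means these few. Any claim that something is new, unique, unknown or untested is made for them only; others in the source may bear on it.

Of the compounds shown here, three have numbers so far. In a functional assay on MCF7 cells (Homo sapiens) for antiproliferative activity, read by MTT assay, with a stated time of 48 h (a higher number here means a weaker inhibitor, a lower number a stronger inhibitor), compound 1 (`Cc1c(Cc2ccccc2)c(=O)oc2cc(OCCOc3no[n+]([O-])c3S(=O)(=O)c3ccccc3)ccc12`) gives 2350 nM as its half-maximal inhibitory concentration. Compound 2 (`COc1cc(OCCOc2no[n+]([O-])c2S(=O)(=O)c2ccccc2)ccc1C(=O)/C=C/c1ccc(F)cc1`) gives 1410 nM in the same test, and compound 3 (`COCCOc1no[n+]([O-])c1S(=O)(=O)c1ccccc1`) gives 3500 nM there. Compound 1 therefore stands in the middle of these numbers, but within the usual scatter of each of the other two, so it cannot be ranked against either. Going by the values given here, these three structures differ in more than one place, so no measured pair isolates the effect of a single group.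

Compound 4 (`Cc1c(Cc2ccc(F)cc2)c(=O)oc2cc(OCCOc3no[n+]([O-])c3S(=O)(=O)c3ccccc3)ccc12`) has not yet been measured. It differs from compound 1 in one place, where benzyl becomes 4-fluorobenzyl: fluoro in place of hydrogen on an aromatic carbon, para to a large group (fluoro in place of hydrogen on an aromatic carbon). Among the compounds with values here, the data hold no measured example of this replacement, so the expectation rests only on the small size of the change and on the value of compound 1 (2350 nM). No step beyond the scatter is expected in this assay, and neither direction is favoured. The estimated step is a 1.1-fold lower number from compound 1 to compound 4 (0.05 log units; within the scatter) and is expected to stay within the scatter. Compound 4 is expected at 2100 nM (estimated range 1050 nM to 4200 nM).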

Compound 4, half-maximal inhibitory concentration: 2850 nM
Compound 4: the middle estimate sits 1.4-fold (0.13 log units) below what was measured; low and high end bracket the measured number.
By their numbers in this assay, from the lowest: compounds 2, 1, 4 and 3 (each within the scatter of the next, the first and the last beyond it).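

In this assay, going by these compounds alone, the pair gives the first reading of a single change, and fluoro in place of hydrogen on the benzyl group amounts to a 1.2-fold higher number from compound 1 to compound 4 (0.08 log units; within the scatter) in that test. The earlier compounds shown here differed in more than one place and could say nothing about any one group, whereas this pair shows that fluoro on an aromatic carbon of this six-membered ring, para to a large group, leaves compound 4 level with compound 1 within the usual scatter. No measured property of either compound bears on this result, and the reading stands as a plain observation on this one pair.

What the compounds shown leave open is whether this position can give a step beyond the scatter at all, since a single small replacement is the only one seen there, and a chloro group, a methoxy group, an amine or a carboxylic acid on the same phenyl ring could read differently. They also leave open whether fluoro would read the same on another core, and what a longer chain in place of the linker would do.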